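The compounds below may be only part of what the source reports. "The series", "measured", "known", "first", "only" and "open" are said of these compounds alone.

Measured compounds:
compound 1, `CCCn1c(CN2CCN(c3ncc(Cl)cn3)CC2)nc2ccccc21`: 794 nM
compound 2, `Cn1c(CN2CCN(c3nc(Cl)ccc3C(F)(F)F)CC2)nc2cc(F)ccc21`: 200 nM
compound 3, `Cn1c(CN2CCN(c3ccccn3)CC2)nc2ccccc21`: 15800 nM

Of the compounds shown here, three have been tested in an assay on CHO cells with metabotropic glutamate receptor 2 (Homo sapiens) as the target, read by FLIPR; a higher number here means that more compound is needed for the effect, a lower number that less compound is needed. Compound 1 gives 794 nM, the second highest of the three numbers. Compound 2 sits nearest to it with 200 nM, a lower number beyond the scatter, while compound 3 lies furthest away with 15800 nM, a higher number well beyond the scatter.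

Compound 4, `COCCn1c(CN2CCN(c3ncc(Cl)cn3)CC2)nc2ccccc21`, has not yet been measured in this assay. It differs from compound 1 in one place: methoxy in place of methyl on a saturated chain carbon, two bonds along the chain from an aromatic nitrogen. Among the measured compounds shown here, no measured pair in this set shows what such a change does, so the step can only be expected, not read off. Because compound 1 stands at 794 nM and the change adds only a single oxygen to the chain, the step is expected to be small, most likely none beyond the scatter in either direction. Compound 4 is therefore estimated at 800 nM, with a range from 300 nM to 2500 nM. That estimate means a step of a 1.0-fold higher number from compound 1 to compound 4 (0.00 log units; within the scatter).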

Compound 4, half-maximal effective concentration: 501 nM
Compound 4: the middle estimate sits 1.6-fold (0.20 log units) above what was measured; measured number inside the range.
By their numbers in this assay, from the lowest: compound 2; then compounds 4 and 1 (each within the scatter of the next); then compound 3.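

In this assay, among the compounds shown here, the swap of propyl for 2-methoxyethyl gives a 1.6-fold lower number from compound 1 to compound 4 (0.20 log units; within the scatter), the first step in this set that can be read between two compounds differing in one place. It shows that this chain position, two bonds along from an aromatic nitrogen, accepts a chain carrying a hydrogen-bond acceptor without a step beyond the scatter, so this assay does not separate the two compounds. No measurement shown here accounts for this outcome.

The compounds shown leave open whether the same position would accept a chain ending in an amine or a carboxylic acid, or a longer chain such as butyl. They also leave open whether 2-methoxyethyl would give a similarly small step on the core of compound 2 or compound 3.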